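The compounds below may be only part of what the source reports. "The series", "measured", "known", "first", "only" and "open" are said of these compounds alone.

Compound 1 `Cc1occc1C(=O)N1CCC(NC(=O)Nc2ccc(C(F)(F)F)cc2)CC1` and compound 2 `Cc1occc1C(=O)N1CCC(NC(=O)Nc2ccc(OC(F)(F)F)cc2)CC1` were measured in a physicochemical assay for lipophilicity, read by HPLC, with a stated time of 90 min, tested at 100 uM; a higher number here means a more lipophilic compound, a lower number a more polar compound. Compound 1 gives 4.19, and compound 2 gives 4.3, the higher of the two numbers, although the change a number 0.11 log units higher from compound 1 to compound 2 (within the scatter) lies within the scatter. Compound 3 `O=C(Nc1ccc(OC(F)(F)F)cc1)NC1CCN(C(=O)c2cc[nH]c2)CC1` differs from compound 2 by 1H-pyrrol-3-yl in place of 2-methylfuran-3-yl on a carbonyl carbon. For the measured compounds named here, no measured step concerns this part of the shared core; the single step known is elsewhere and small. An estimate for compound 3 is therefore 3.6, spanning 3.2 to 4. The expected step of a number 0.70 log units lower from compound 2 to compound 3 (beyond the scatter) is downward, beyond the scatter.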

Compound 3, partition coefficient: 3.34
The estimate for compound 3 lay 0.26 log units above the measured number; the measured number falls inside the stated range.
By their numbers in this assay, from the lowest: compound 3; then compounds 1 and 2 (each within the scatter of the next).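

In this assay, 1H-pyrrol-3-yl in place of 2-methylfuran-3-yl on the carbonyl carbon gives a number 0.96 log units lower from compound 2 to compound 3 (beyond the scatter), so a change at this position moves the number clearly, unlike the change on the aromatic carbon, a number 0.11 log units higher from compound 1 to compound 2 (within the scatter). The two groups differ at once in their ring hetero atom, in the methyl and in their hydrogen-bond donors and acceptors, and this single step cannot separate these differences. No measurement at hand bears on the cause of the step. As far as these compounds go, what remains open is how furan-3-yl without the methyl, or a phenyl, on the same carbonyl carbon would read in this assay.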